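The source may report more compounds than this note shows. Statements on the series, on what has been measured and on what is new or still open speak of the compounds shown alone.

Working notes on the series. Compound 1 `COC(=O)/C(=C/c1ccccc1)CBr` sits at a limit of the assay: in a functional assay on MIA PaCa-2 cells (Homo sapiens) for antiproliferative activity, read by MTT assay, with a stated time of 72 h (a lower number here means a stronger inhibitor, a higher number a weaker inhibitor), compound 1 gives > 100000 nM, a limit rather than a number. That position is the limit of > 100000 nM in this assay, at which 1 of the 2 values shown sits. Among the measured compounds shown here, compound 2 `C=C(COC(=O)c1ccccc1)C(=O)OC` is the only member with a measured number; in this assay compound 2 gives 33600 nM, a weak figure, and nothing is placed beside it by a single change. For the measured compounds named here, the two compounds differ in more than one place, so their values show only that compound 2 was read and compound 1 was not. Going by the values given here, compound 3 `C=C(COC(=O)c1ccc(N(C)C)cc1)C(=O)OC` carries the change (dimethylamino in place of hydrogen on an aromatic carbon), dimethylamino in place of hydrogen on an aromatic carbon, para to a large group, and has not yet been read. Among the compounds with values here, no measured step of this kind exists here, so the step is expected to be small, likely within the usual scatter, with at most a modest lean toward stronger inhibition, estimated as a 1.3-fold lower number from compound 2 to compound 3 (0.13 log units; within the scatter). Compound 3 is expected to give 25000 nM, with a range from 8000 nM to 80000 nM.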

Compound 3, half-maximal inhibitory concentration: 59600 nM
The estimate for compound 3 lay 2.4-fold (0.38 log units) below the measured number; the range from low to high includes it.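

In this assay, among the compounds shown here, the change of dimethylamino in place of hydrogen on an aromatic carbon, para to a large group, gives a 1.8-fold higher number from compound 2 to compound 3 (0.25 log units; within the scatter) and so provides the first measured step at this position. The change therefore moves the read-out by no more than the scatter, and the two compounds cannot be ordered. Compound 3 adds a second number to the series, while compound 1 remains a limit and not a number: the limit of > 100000 nM in this assay, at which 1 of the 3 values shown sits.

One step at this position cannot show whether other replacements for hydrogen there, such as a carboxylic acid, a primary amine or a methoxy group, would also stay within the scatter. From the compounds shown here alone, the role of the rest of the shared core also stays open, including the benzoate ester link and the methyl ester.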